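A ring swap on compound 2

This account rests on a few compounds, and the source may have more. Where it says the series, first, only, none or still open, it means among the compounds named here.

compound 1 `C=CS(=O)(=O)NC/C=C/c1cc(OC)cc(O)c1C(=O)OCC(C)c1ccccc1` gives 16.7% in growth inhibition
compound 2 `COc1cc(O)c(C(=O)OCC(C)c2ccccc2)c(/C=C/CN2C(=O)C=CC2=O)c1` gives 74.9% in growth inhibition

In a functional assay on K562 cells (Homo sapiens) for inhibition, read by luminescence, with a stated time of 72 h, tested at 5 uM (on this read-out higher numbers stand for more inhibition of growth at the one concentration tested and lower numbers for less inhibition of growth), compound 2 stands highest of the two measured compounds, with 74.9% as its reading. Compound 3 `COc1cc(O)c(C(=O)OCC2CCCCC2)c(/C=C/CN2C(=O)C=CC2=O)c1` differs from compound 2 at one place cyclohexyl in place of 1-phenylethyl on a saturated chain carbon bound to an oxygen next to a carbonyl group where cyclohexyl stands in place of 1-phenylethyl, on a saturated chain carbon bound to an oxygen next to a carbonyl group.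

For the measured compounds named here, the only measured step, a number 58.2 percentage points higher from compound 1 to compound 2 (beyond the scatter), was large and beyond the scatter, but it lay at another place. That place stays unchanged in compound 3, so the reading should remain near compound 2 at 74.9% as a starting point. Going by the values given here, no measured step shows what the new change does. The expected change is a number 6.9 percentage points lower from compound 2 to compound 3 (within the scatter) and so no step beyond the scatter is expected. For compound 3 the estimated value is 68% with an expected range from 45% to 85% at this single concentration.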

Compound 3, percent growth inhibition at one concentration: 85.1%
For compound 3 the middle estimate is 17.1 percentage points below the measured one; the whole stated range lies below it.
By their numbers in this assay, from the lowest: compound 1; then compound 2; then compound 3.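

In this assay, the group on the saturated chain carbon bound to an oxygen next to a carbonyl group proves able to shift the reading: with cyclohexyl in place of 1-phenylethyl, the result is a number 10.2 percentage points higher from compound 2 to compound 3 (beyond the scatter) and the step is modest. Earlier compounds showed no change at this place, and this pair shows that an aromatic ring here is not required for high growth inhibition at the one concentration tested. Nothing available explains the higher reading with cyclohexyl.

Still open, as far as these compounds go, is whether a smaller ring such as cyclopentyl, an open hexyl chain, or a cyclohexyl ring carrying an amine would keep or raise the reading at this place. A single concentration also leaves open how compound 2 and compound 3 compare at lower concentrations.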